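A few compounds are considered here, and "the series" means these few. Any claim that something is new, unique, unknown or untested is made for them only; others in the source may bear on it.

In a functional assay on MCF7 cells (Homo sapiens) for antiproliferative activity, read by MTT assay, with a stated time of 48 h (on this read-out lower numbers stand for stronger inhibition and higher numbers for weaker inhibition), compound 1 `COC(=O)[C@H](CC(C)C)NC(=O)c1ccc(Oc2nc3ccccc3nc2C)cc1` gives 25500 nM and compound 2 `CC[C@@H](C)[C@H](NC(=O)c1ccc(Oc2nc3ccccc3nc2C)cc1)C(=O)OC` gives 36100 nM as measured values. Compound 3 `COC(=O)[C@H](CC(C)C)NC(=O)c1ccc(Oc2nc3ccccc3nc2NC(C)(C)C)cc1` has only a limit, not a number: > 50000 nM is what stands for it. Compound 4 `CC(C)C[C@H](NC(=O)c1ccc(Oc2nc3ccccc3nc2NC(C)(C)C)cc1)C(=O)O` follows from compound 3 by hydrogen in place of methyl on an oxygen next to a carbonyl group with hydrogen in place of methyl on an oxygen next to a carbonyl group, methoxycarbonyl to carboxy. The measured steps lie elsewhere: a 1.4-fold higher number from compound 1 to compound 2 (0.15 log units; within the scatter) for sec-butyl in place of isobutyl and an at least 1.9-fold higher number from compound 1 to compound 3 (0.29 log units; that floor lies within the scatter) for (tert-butyl)amino in place of methyl. Among the compounds with values here, no measured step covers this change, so nothing beyond the scatter is expected in this assay. The expected step is a number no higher from compound 3 to compound 4 (the limit leaves the size open) on this estimate. For compound 4 the estimated value is 50000 nM with an expected range from 25000 nM to 100000 nM in view.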

Compound 4, half-maximal inhibitory concentration: 40300 nM
Estimate against measurement, compound 4: 1.2-fold (0.09 log units) above; the range from low to high includes it.
By their numbers in this assay, from the lowest: compounds 1, 2 and 4 (each within the scatter of the next). At a limit, above all of these: compound 3.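

Methoxycarbonyl to carboxy is the first change shown on this oxygen next to a carbonyl group, and in this assay it reads as an at least 1.2-fold lower number from compound 3 to compound 4 (0.09 log units; that floor lies within the scatter). With the (tert-butyl)amino group in place, carboxy in compound 4 gives a measured number, which methoxycarbonyl in compound 3 does not. The true size of the step stays open, since compound 3 stands at a limit of the assay: the limit of > 50000 nM in this assay, at which 1 of the 4 values shown sits.

From the compounds shown here alone, whether carboxy gives a similar result with methyl in place of (tert-butyl)amino remains open. So does the outcome with a primary amide or an ethyl ester at this place.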